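Trifluoromethoxy in Place of Trifluoromethyl on the Sulfonyl Sulfur

The source may hold more compounds than are shown below. What is called first, only, known or untested is meant among the compounds shown, and "the series" means these compounds.

In a functional assay on CWR22R cells (Homo sapiens) for antiproliferative activity, read by fluorescence and propidium iodide staining, with a stated time of 96 h (on this read-out lower numbers stand for stronger inhibition and higher numbers for weaker inhibition), compound 1 `CC(O)(CS(=O)(=O)c1cccc(C(F)(F)F)c1)C(=O)Nc1cc(C(F)(F)F)cc(C(F)(F)F)c1` gives 10300 nM, and compound 2 `CC(O)(CS(=O)(=O)c1ccccc1C(F)(F)F)C(=O)Nc1cc(C(F)(F)F)cc(C(F)(F)F)c1` gives 9450 nM. These two values lie within the scatter of each other, so compound 2 cannot be separated from compound 1. The next structure, compound 3 `CC(O)(CS(=O)(=O)c1cccc(OC(F)(F)F)c1)C(=O)Nc1cc(C(F)(F)F)cc(C(F)(F)F)c1`, carries 3-(trifluoromethoxy)phenyl in place of 2-(trifluoromethyl)phenyl on a sulfonyl sulfur. Going by the values given here, only one measured step bears on this change, a 1.1-fold lower number from compound 1 to compound 2 (0.04 log units; within the scatter), and it also alters the group on the sulfonyl sulfur. Among the compounds with values here, no measured compound carries trifluoromethoxy, so that group itself remains untested in this assay. With that single small step as the guide, no shift in either direction is expected from the level of compound 2 at 9450 nM. The expected step is a 1.1-fold higher number from compound 2 to compound 3 (0.02 log units; within the scatter), which means no change beyond the scatter. Compound 3 is estimated at 10000 nM, with an expected range of 5000 nM to 20000 nM.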

Compound 3, half-maximal inhibitory concentration: 12800 nM
Compound 3: the middle estimate sits 1.3-fold (0.11 log units) below what was measured; the range from low to high includes it.
By their numbers in this assay, from the lowest: compounds 2, 1 and 3 (each within the scatter of the next).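

In this assay the direct exchange of trifluoromethoxy for trifluoromethyl on an aromatic carbon gives a 1.2-fold higher number from compound 1 to compound 3 (0.09 log units; within the scatter) and so does not separate the two groups at this place. With 3-(trifluoromethoxy)phenyl in place of 2-(trifluoromethyl)phenyl on a sulfonyl sulfur, the result is a 1.4-fold higher number from compound 2 to compound 3 (0.13 log units; within the scatter) and thus also no separable change, so all three groups tried on the sulfonyl sulfur remain within the scatter of one another. No independent evidence bears on this result. The compounds shown leave open whether a different kind of substituent on this aromatic ring, such as an amine, a carboxylic acid or a nitrile, would move the number beyond the scatter. They also leave open whether replacing the aromatic ring on the sulfonyl sulfur with a longer saturated chain would do so.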